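Trifluoromethyl to Hydrogen: An Expected Cytotoxicity Outcome

This account rests on a few compounds, and the source may have more. Where it says the series, first, only, none or still open, it means among the compounds named here.

Measured compounds in a functional assay on KB cells (Homo sapiens) for cytotoxicity, read by MTT assay, with a stated time of 72 h; a higher number here means a weaker inhibitor, a lower number a stronger inhibitor:
compound 1 `COc1cc2ncnc(NNC(=S)NC(=O)c3ccc(C(F)(F)F)cc3)c2cc1OC` gives 8840 nM
compound 2 `COc1cc2ncnc(NNC(=S)NC(=O)c3ccccc3C)c2cc1OC` gives 11400 nM
compound 3 `Cc1ccc(C(=O)NC(=S)NNc2ncnc3ccccc23)cc1` gives 10100 nM

Compound 1 has the lowest of the three numbers, but compound 3 and compound 2 both sit within the scatter of it, so no order can be read among them. Compound 4 `COc1cc2ncnc(NNC(=S)NC(=O)c3ccccc3)c2cc1OC` differs from compound 1 in one place: hydrogen in place of trifluoromethyl on an aromatic carbon. Among the compounds with values here, the one measured step that bears on a change at this aromatic carbon is a 1.3-fold higher number from compound 1 to compound 2 (0.11 log units; within the scatter), which swapped the whole aryl group and still stayed within the scatter. Compound 3, which lacks the two methoxy groups as well, gives a value close to compound 1. Removing only the trifluoromethyl is therefore expected to leave this assay essentially unchanged, with a step of a 1.1-fold higher number from compound 1 to compound 4 (0.05 log units; within the scatter). Compound 4 is estimated at 10000 nM, between 5000 nM and 20000 nM.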

Compound 4, half-maximal inhibitory concentration: 3770 nM
Compound 4: the middle estimate sits 2.7-fold (0.42 log units) above what was measured; measured number outside the range, below it.
By their numbers in this assay, from the lowest: compound 4; then compounds 1, 3 and 2 (each within the scatter of the next).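

In this assay, removing the group from the aromatic ring gives a 2.3-fold lower number from compound 1 to compound 4 (0.37 log units; beyond the scatter), and a second removal, of methyl rather than trifluoromethyl, gives a 3.0-fold lower number from compound 2 to compound 4 (0.48 log units; beyond the scatter). Both steps lie beyond the scatter, so the unsubstituted phenyl of compound 4 is a stronger inhibitor than the substituted rings of compound 1 and compound 2, a difference the earlier comparison did not reveal. No evidence on the cause of this is available. Going by these compounds, whether an amine or a carboxylic acid on this ring would also give a higher number than hydrogen remains open. So does whether the same step would hold on a core without the two methoxy groups.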